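The source may hold more compounds than are shown below. What is called first, only, known or untested is meant among the compounds shown, and "the series" means these compounds.

In an ADME assay on MT4 cells (Homo sapiens) for cytotoxicity, read by MTT assay (on this read-out lower numbers stand for higher toxicity in this test and higher numbers for lower toxicity in this test), two compounds sharing one core have been measured: compound 1 (`Cc1cc(C)cc(S(=O)(=O)c2c(C(=O)NCc3ccccc3F)[nH]c3ccc(Cl)cc23)c1`) and compound 2 (`Cc1cc(C)cc(S(=O)(=O)c2c(C(=O)NCc3ccccc3[N+](=O)[O-])[nH]c3ccc(Cl)cc23)c1`). Compound 1 gives > 53000 nM, which is a limit of the assay and not a number. Compound 2 gives > 50200 nM, which is also a limit. Compound 2 therefore has no exact position on the numbers shown, and the only other value available is a limit too.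

Compound 3 (`Cc1cc(C)cc(CNC(=O)c2[nH]c3ccc(Cl)cc3c2S(=O)(=O)c2cc(C)cc(C)c2)c1`) has not yet been measured. It carries 3,5-dimethylphenyl in place of 2-nitrophenyl on a saturated chain carbon bound to an amide-type nitrogen. Going by the values given here, the only measured step available is a step that the two limits leave unreadable from compound 1 to compound 2, and it offers no size to carry over. With no readable change on record, no step beyond the usual scatter is expected in this assay, and no direction can be assigned. The estimated step is an at least 1.1-fold lower number from compound 2 to compound 3 (0.04 log units; that floor lies within the scatter). For compound 3 the expected value is 45000 nM, with an estimated range from 15000 nM to 55000 nM.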

Compound 3, half-maximal cytotoxic concentration: > 51900 nM
Compound 3 gave a limit, no number (the forecaster's own chance of this, stated with the estimate: 65%); at least 1.1-fold (0.06 log units) between middle value and limit.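

In this assay, going by these compounds alone, compound 1, compound 2 and compound 3 all stand as limits and not as numbers, so no step among them can be read. The compounds shown leave open whether 2-fluorophenyl, 2-nitrophenyl or 3,5-dimethylphenyl on the saturated chain carbon bound to the amide-type nitrogen changes the read-out at all.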